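Chloro to Methyl on Two Related Cores

The source may hold more compounds than are shown below. What is called first, only, known or untested is meant among the compounds shown, and "the series" means these compounds.

Measured in a physicochemical assay for lipophilicity, at pH 3; on this read-out lower numbers stand for lower lipophilicity and higher numbers for higher lipophilicity:
compound 1 `CC(C)Nc1nc(NCc2ccco2)c2cccc(Cl)c2n1`: 2.38
compound 2 `CC(C)Nc1nc(NCc2ccco2)c2ccc(Cl)cc2n1`: 2.51
compound 3 `Cc1cccc2c(NCc3ccco3)nc(NC(C)C)nc12`: 1.57

Compounds 1 and 2 share the same atoms joined differently; the difference between the two cores is not broken down here, and their values lie within the scatter of each other. Compound 3 differs from compound 1 by methyl in place of chloro on an aromatic carbon, and this change gave a number 0.81 log units lower from compound 1 to compound 3 (beyond the scatter). Compound 4 `Cc1ccc2c(NCc3ccco3)nc(NC(C)C)nc2c1`, not yet measured, differs from compound 2 by methyl in place of chloro on an aromatic carbon. The change is the same kind as before, but in compound 3 the position is ortho to a fused ring and meta to a fused ring, whereas in compound 4 it is meta to a fused ring and para to a fused ring. Resting on the step from compound 1 to compound 3, the expected step is a number 0.81 log units lower from compound 2 to compound 4 (beyond the scatter) in this assay. Compound 4 is thus estimated at 1.7, between 1.4 and 2.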

Compound 4, distribution coefficient: 1.58
Compound 4: middle estimate off by 0.12 log units, on the high side; low and high end bracket the measured number.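

In this assay, methyl in place of chloro on an aromatic carbon gave a number 0.93 log units lower from compound 2 to compound 4 (beyond the scatter), and the earlier pair gave a number 0.81 log units lower from compound 1 to compound 3 (beyond the scatter), so the change carried over between these two related cores in the same direction, with both steps beyond the scatter. Going by these compounds alone, these are only two pairs, each with the change at a single place on its core, so they do not establish a rule for the whole series. Nothing measured here explains why the number falls with this change.

On these data alone, whether the step would also hold at other places on the shared core remains open. So does what an amine, a methoxy group or a longer chain would do in place of the chloro.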